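The source may hold more compounds than are shown below. What is called first, only, known or untested is meant among the compounds shown, and "the series" means these compounds.

In a functional assay on HL-60 cells (Homo sapiens) for antiproliferative activity, read by XTT assay, with a stated time of 72 h (a lower number here means a stronger inhibitor, a higher number a weaker inhibitor), compound 1 (`CN(C)c1ncnc2c1c(-c1cc3ccccc3o1)cn2[C@@H]1O[C@H](CO)[C@@H](O)[C@H]1O`) gives > 20000 nM as a limit, not a number. Compound 2 (`Cc1nc(N)c2c(-c3ccoc3)cn([C@@H]3O[C@H](CO)[C@@H](O)[C@H]3O)c2n1`) gives > 20000 nM as a limit too. Compound 3 (`COc1nc(N)nc2c1c(-c1cc3ccccc3o1)cn2[C@@H]1O[C@H](CO)[C@@H](O)[C@H]1O`) gives > 20000 nM as a limit as well. Only the limit of > 20000 nM in this assay, at which 3 of the 3 values shown sit, is known so far, so compound 2 stands without a number of its own.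

Compound 4 (`Cc1nc(N)c2c(I)cn([C@@H]3O[C@H](CO)[C@@H](O)[C@H]3O)c2n1`) has iodo in place of furan-3-yl on an aromatic carbon. No measured step sizes this change in this assay and a moderate gain in strength is expected, with another reading at the limit quite possible. The estimate means an at least 2.5-fold lower number from compound 2 to compound 4 (0.39 log units; beyond the scatter) as an expected step toward stronger inhibition. For compound 4 in this assay the estimated value is 8000 nM (expected range 1000 nM to 20000 nM).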

Compound 4, half-maximal inhibitory concentration: 2050 nM
Compound 4: middle estimate off by 3.9-fold (0.59 log units), on the high side; the range from low to high includes it.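

Among the compounds shown here, at the aromatic carbon two ring bonds from the ring nitrogen, iodo in place of furan-3-yl gives the only reading under the limit in this assay, with an at least 9.7-fold lower number from compound 2 to compound 4 (0.98 log units; beyond the scatter). Activity at this position therefore depends on the group it carries, and a single iodine atom is enough to bring a measurable value. The step gives only a minimum size because compound 2 has no number of its own: the limit of > 20000 nM in this assay, at which 3 of the 4 values shown sit.

On these data alone, whether bromo or an ethynyl group on this carbon would give a similar value remains open. So does whether the step would hold with the methyl or amino group of the core of compound 4 replaced.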